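Ester in place of hydroxy ether on the shared core

The compounds below may be only part of what the source reports. "The series", "measured", "known", "first", "only" and "open" are said of these compounds alone.

Compound 1 `CC(C)=CC[C@@H](OC[C@@H](C)O)C1=CC(=O)c2c(O)ccc(O)c2C1=O` gives the lowest number of the three measured in a functional assay on HeLa cells (Homo sapiens) for cytotoxicity, read by MTT assay (a higher number here means a weaker inhibitor, a lower number a stronger inhibitor), at 22500 nM. Compound 2 `COC(C)CO[C@H](CC=C(C)C)C1=CC(=O)c2c(O)ccc(O)c2C1=O` gives 53400 nM in this assay, and compound 3 `CC(C)=CC[C@@H](OC(=O)CC(C)(O)c1ccccc1)C1=CC(=O)c2c(O)ccc(O)c2C1=O` gives 85700 nM. Among the compounds with values here, the one single-point step recorded is a 2.4-fold higher number from compound 1 to compound 2 (0.38 log units; beyond the scatter), so capping the hydroxyl as a methyl ether already pushes the number up beyond the scatter.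

Compound 4 `CC(C)=CC[C@@H](OC(=O)C1CCCO1)C1=CC(=O)c2c(O)ccc(O)c2C1=O` differs from compound 1 by (oxolan-2-yl)carbonyl in place of 2-hydroxypropyl on an oxygen on a saturated carbon. Within the data shown here, no measured pair isolates this exact change. The step from compound 1 to compound 2 bears on it in that the hydroxyl donor is lost; compound 3, the only other ester in the set, carries a hydroxyl yet gives the highest number of the three, though it is not a single-point neighbour of compound 1. On this basis a modest rise in this assay is expected for compound 4, roughly the size seen from compound 1 to compound 2, i.e. a 2.2-fold higher number from compound 1 to compound 4 (0.35 log units; beyond the scatter). Compound 4 is accordingly estimated at 50000 nM, with a range from 20000 nM to 125000 nM.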

Compound 4, half-maximal inhibitory concentration: 17000 nM
Compound 4: middle estimate off by 2.9-fold (0.47 log units), on the high side; the measured number lies below the stated range.
By their numbers in this assay, from the lowest: compounds 4 and 1 (each within the scatter of the next); then compounds 2 and 3 (each within the scatter of the next).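

In this assay the ester of compound 4 does not separate from the hydroxy ether of compound 1 (a 1.3-fold lower number from compound 1 to compound 4 (0.12 log units; within the scatter)), so this oxygen can carry (oxolan-2-yl)carbonyl, with no hydrogen-bond donor, and the number stays within the scatter; compound 2 therefore cannot be read as showing that any loss of the donor raises the number. The ester link alone does not set the number either, as the acyl group on the carbonyl carbon matters (a 5.0-fold lower number from compound 3 to compound 4 (0.70 log units; beyond the scatter)), and the gap to the methyl ether is beyond the scatter (a 3.1-fold lower number from compound 2 to compound 4 (0.50 log units; beyond the scatter)). Nothing available explains these differences.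

Open, going by these compounds, is whether the five-membered ring itself counts, which an acetyl or a butanoyl ester would test. Also open, on these data alone, is how an amine or a carboxylic acid on this chain would read in this assay.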